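A few compounds are considered here, and "the series" means these few. Any claim that something is new, unique, unknown or untested is made for them only; others in the source may bear on it.

- compound 1 `CN(C)CCCN(/N=N/c1ccc([N+](=O)[O-])cc1)c1ccccc1`: 36000 nM
- compound 2 `O=[N+]([O-])c1cccc(/N=N/N2CCCC2)c1`: 42000 nM
- compound 3 `FC(F)(F)c1cccc(/N=N/c2ccc(NC[C@@H]3CCCN4CCCC[C@H]34)c3c2CCCC3)c1`: 14000 nM

In an ADME assay on BHK-21 cells (Mesocricetus auratus) for cytotoxicity, read by MTT assay, with a stated time of 96 h (on this read-out higher numbers stand for lower toxicity in this test and lower numbers for higher toxicity in this test), compound 1 at 36000 nM cannot be told apart from compound 2 at 42000 nM, as the two lie within the usual scatter of each other. Compound 3 at 14000 nM gives a lower number than both, a gap beyond the scatter.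

The next compound to be tested is compound 4 `Cc1ccc(/N=N/N(CCCN(C)C)c2ccccc2)cc1`. It differs from compound 1 in one place, with methyl in place of nitro on an aromatic carbon, para to a large group (methyl in place of nitro on an aromatic carbon). Going by the values given here, no measured pair shows this exchange, so the data give no direct guide to its size, and the expectation starts from compound 1 at 36000 nM. No step beyond the scatter is expected in this assay. The estimated step is a 1.1-fold higher number from compound 1 to compound 4 (0.05 log units; within the scatter), which stays within the scatter. Compound 4 is expected at an estimated 40000 nM, with a range of 15000 nM to 100000 nM.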

Compound 4, half-maximal cytotoxic concentration: > 100000 nM
Compound 4 was reported as a limit; the forecaster's own chance of this, stated with the estimate: 15%; middle value at least 2.5-fold (0.39 log units) away from the limit.
By their numbers in this assay, from the lowest: compound 3; then compounds 1 and 2 (each within the scatter of the next). At a limit, above all of these: compound 4.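

In this assay, going by these compounds alone, methyl in place of nitro on an aromatic carbon, para to a large group, gives the first one-place comparison in this set: an at least 2.7-fold higher number from compound 1 to compound 4 (0.44 log units; beyond the scatter). This shows that the position is not silent, since this single exchange moves the number beyond the scatter, towards lower toxicity in this test. As far as these compounds go, compound 4 gives > 100000 nM, which is a limit and not a number, so the full size of the step stays unknown: the limit of > 100000 nM in this assay, at which 1 of the 4 values shown sits.

This one pair cannot separate the loss of nitro from the arrival of methyl, and a methoxy group, a chlorine or an amine at the same place would be needed to tell the two apart. From the compounds shown here alone, whether the exchange acts the same way in compound 2, which also carries a nitro group, stays open.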